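Amide nitrogen substituent in a dihydrofuran carboxamide series

The compounds below may be only part of what the source reports. "The series", "measured", "known", "first", "only" and "open" are said of these compounds alone.

Measured so far in a functional assay on QGY7701 cells (Homo sapiens) for cytotoxicity, read by MTT assay, with a stated time of 24 h; on this read-out lower numbers stand for stronger inhibition and higher numbers for weaker inhibition:
- compound 1, `C=CC1=C(C(=O)NCc2ccc(Cl)cc2)C(c2ccc(OC)c(OC)c2)OC1`: > 100000 nM
- compound 2, `C=CC1=C(C(=O)NC(C)(C)C)C(c2ccc(OC)cc2)OC1`: > 100000 nM
- compound 3, `C=CC1=C(C(=O)Nc2ccc(C)cc2)C(c2ccc(F)cc2)OC1`: 59200 nM

Compound 1 carries a 4-chlorobenzyl group on the amide nitrogen and its value, > 100000 nM, is a limit of this assay, not a number. Compound 2, with a tert-butyl group on the amide nitrogen, likewise gives only the limit > 100000 nM. Within the data shown here, compound 3 is the one compound of the three for which this assay returns a number, 59200 nM; the two others sit at the limit of > 100000 nM in this assay, at which 2 of the 3 values shown sit, so no ordering among the three can be drawn beyond that.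

Compound 4, `C=CC1=C(C(=O)NCc2ccc(C)cc2)C(c2ccc(F)cc2)OC1`, has not yet been measured. It differs from compound 3 in one place: 4-methylbenzyl in place of 4-methylphenyl on an amide-type nitrogen. Among the measured compounds shown here, no step between two measured compounds is available for this change, so the expectation rests on the pattern that both compounds with a non-aromatic carbon on the amide nitrogen, compound 1 and compound 2, reach only the limit. The step from compound 3 to compound 4 is therefore expected to run toward weaker inhibition, estimated as a 1.5-fold higher number from compound 3 to compound 4 (0.18 log units; within the scatter), though the scatter of this assay leaves room for no real change. Compound 4 is expected to give about 90000 nM, within a range of 35000 nM to 250000 nM, with a fair chance that only a limit is returned.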

Compound 4, half-maximal inhibitory concentration: 62100 nM
Compound 4: middle estimate off by 1.4-fold (0.16 log units), on the high side; the measured number falls inside the stated range.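

In this assay, the amide nitrogen position now has its first readable step, with 4-methylbenzyl in place of 4-methylphenyl on an amide-type nitrogen: a 1.0-fold higher number from compound 3 to compound 4 (0.02 log units; within the scatter). This step lies within the scatter, so compound 3 and compound 4 cannot be separated by this change, and a 4-methylbenzyl group on this nitrogen does not by itself bring the read-out to the limit. Compound 1 and compound 2 remain limits of this assay, not numbers, and each differs from compound 4 in more than one place, so neither can be set against it: the limit of > 100000 nM in this assay, at which 2 of the 4 values shown sit.

The compounds shown leave open whether a longer chain such as 2-phenylethyl, or an amine or a carboxylic acid carried on the benzyl ring, would move the number at this position. They also leave open how the 4-fluorophenyl group on the shared core contributes, since no pair shown changes that group alone while the amide nitrogen substituent stays the same.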